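Macrocyclic series: benzothiophene in place of hydroxyphenyl

The compounds below may be only part of what the source reports. "The series", "measured", "known", "first", "only" and "open" are said of these compounds alone.

Of the compounds shown here, two have numbers so far. Compound 1 `CC(C)[C@H]1NC(=O)[C@@H](Cc2ccc(O)cc2)NCCOc2ccccc2/C=C/CNC(=O)[C@H](CO)NC1=O` gives 650 nM in an assay on isolated protein for displacement of a labelled ligand from Motilin receptor (Homo sapiens); a higher number here means a weaker inhibitor, a lower number a stronger inhibitor. Compound 2 `CCC[C@@H]1NC(=O)[C@@H](C(C)C)NC(=O)[C@@H](Cc2ccc(O)cc2)NCCOc2ccccc2CCCNC1=O` gives 55 nM in this assay and stands lowest of the two numbers; its nearest neighbour is compound 1, whose number is higher by a margin beyond the scatter. Going by the values given here, compounds 1 and 2 differ in more than one place, so no single step between measured compounds is available.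

Compound 3 `CCC[C@@H]1NC(=O)[C@@H](C(C)C)NC(=O)[C@@H](Cc2csc3ccccc23)NCCOc2ccccc2CCCNC1=O` follows from compound 2 by one change: 1-benzothiophen-3-yl in place of 4-hydroxyphenyl on a saturated chain carbon bound to a saturated ring carbon. Among the compounds with values here, nothing among the measured compounds isolates this kind of exchange, so there is no measured step to lean on. The expectation for the step from compound 2 to compound 3 in this assay is a 2.0-fold higher number from compound 2 to compound 3 (0.30 log units; within the scatter), a modest move toward a higher number, with wide uncertainty in either direction. On that basis compound 3 is estimated at 110 nM in this assay, with a range from 20 nM to 600 nM.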

Compound 3, inhibition constant: 11 nM
Estimate against measurement, compound 3: 10-fold (1.00 log units) above, and the stated range ends above it.
By their numbers in this assay, from the lowest: compound 3; then compound 2; then compound 1.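

In this assay, going by these compounds alone, 1-benzothiophen-3-yl in place of 4-hydroxyphenyl on a saturated chain carbon bound to a saturated ring carbon gives a 5.0-fold lower number from compound 2 to compound 3 (0.70 log units; beyond the scatter) and provides the first single-place comparison. On the core of compound 2, this position therefore tolerates loss of the hydroxyl of 4-hydroxyphenyl, and with it the hydrogen-bond donor, while the group grows from 7 to 9 heavy atoms and the number falls beyond the scatter. Nothing at hand bears on the origin of this step.

The compounds shown do not separate the contribution of the sulfur-containing five-membered ring from that of the second aromatic ring, a question that a 2-naphthyl, 1-benzofuran-3-yl or indol-3-yl group at the same place would address, and they do not show whether a plain phenyl group, lacking the hydroxyl, would account for part of the step. Compound 1 differs from both other compounds in more than one place, so whether the exchange carries over to its core cannot be read.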